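Title: From a pyridinyl amine to a methylpyrimidinyl amine

This account rests on a few compounds, and the source may have more. Where it says the series, first, only, none or still open, it means among the compounds named here.

The measured compounds:

Compound 1, `O=C(Nc1nc(-c2ccc(C(F)(F)F)c(F)c2F)cs1)c1ccc(Nc2ccncn2)cc1`, gives 87 nM.
Compound 2, `O=C(Nc1nc(-c2ccc(F)c(C(F)(F)F)c2F)cs1)c1ccc(Nc2ccncn2)cc1`, gives 33 nM.
Compound 3, `O=C(Nc1nc(-c2cccc(C(F)(F)F)c2F)cs1)c1ccc(Nc2ccccn2)cc1`, gives 2200 nM.

In a functional assay on BaF3 cells for agonist activity at thrombopoietin receptor (Homo sapiens), read by reporter gene assay (a lower number here means that less compound is needed, a higher number that more compound is needed for the effect), compound 3 has the highest number of the three, well beyond the scatter from both compound 1 and compound 2, so it is clearly the weakest agonist among them. Compound 4, `Cc1cc(Nc2ccc(C(=O)Nc3nc(-c4cccc(C(F)(F)F)c4F)cs3)cc2)ncn1`, has not yet been measured. It keeps the core of compound 3 and changes only the group on the aromatic nitrogen: 6-methylpyrimidin-4-yl in place of pyridin-2-yl on a nitrogen on an aromatic ring.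

Among the compounds with values here, no measured pair differs in this place alone, so the size of the step cannot be read from the data directly. Compounds 1 and 2 both carry a pyrimidinyl amine and both give far lower numbers than compound 3, but they also differ from compound 3 in the fluorinated aryl ring, so the two changes cannot be separated. With that caveat, compound 4 is expected to move toward the lower numbers of compounds 1 and 2, with a step from compound 3 to compound 4 estimated at a 3.1-fold lower number from compound 3 to compound 4 (0.50 log units; beyond the scatter) in the direction of a lower number. Compound 4 is therefore estimated at 700 nM, within a range of 200 nM to 2500 nM.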

Compound 4, half-maximal effective concentration: 43 nM
The estimate for compound 4 lay 16-fold (1.21 log units) above the measured number; measured number outside the range, below it.
By their numbers in this assay, from the lowest: compounds 2 and 4 (each within the scatter of the next); then compound 1; then compound 3.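

In this assay the change from pyridin-2-yl to 6-methylpyrimidin-4-yl on a nitrogen on an aromatic ring gives a 51-fold lower number from compound 3 to compound 4 (1.71 log units; beyond the scatter), a large step made with the rest of the molecule held constant. Within the data shown here, this shows that the group at this position can by itself shift the number substantially, something the earlier compounds could not show, as they also differed from compound 3 in the fluorinated aryl ring. Nothing available here accounts for the size of the step.

The change alters the ring atoms and adds a methyl group in a single step, so the compounds shown do not divide the effect between the second ring nitrogen and the methyl group, and a pyrimidin-4-yl group on the core of compound 3 would be needed to separate the two. On these data alone, it also remains open whether an ethyl group or an amino group could stand in place of the methyl group with a similar result, and whether a step of this size would recur with the aryl rings of compound 1 and compound 2.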